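Replacing the 2-chlorophenyl group of compound 1

This account rests on a few compounds, and the source may have more. Where it says the series, first, only, none or still open, it means among the compounds named here.

Measured so far in a functional assay on HCT-15 cells (Homo sapiens) for cytotoxicity, in the presence of a further agent that is not named here; a higher number here means a weaker inhibitor, a lower number a stronger inhibitor:
Compound 1 `Clc1ccc(-c2cc(-c3ccsc3)nc(-c3ccccc3Cl)c2)o1`: 4570 nM
Compound 2 `Clc1ccc(-c2cc(-c3cccnc3)nc(-c3cccs3)c2)o1`: 1240 nM
Compound 3 `Clc1ccc(-c2cc(-c3ccoc3)cc(-c3cccs3)n2)cc1`: 50000 nM

Compound 1 stands in the middle of these three values, with compound 2 at a lower number and compound 3 at a higher one. Compound 4 `Cc1ccc(-c2cc(-c3ccc(Cl)o3)cc(-c3ccsc3)n2)o1` has not yet been measured. It carries 5-methylfuran-2-yl in place of the 2-chlorophenyl of compound 1, on an aromatic carbon next to the ring nitrogen: 5-methylfuran-2-yl in place of 2-chlorophenyl on an aromatic carbon. The 5-chlorofuran-2-yl group stays.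

For the measured compounds named here, no measured pair isolates this change, so the evidence is indirect. Compound 1 at 4570 nM and compound 2 at 1240 nM both carry the 5-chlorofuran-2-yl group, while compound 3, which lacks it, gives 50000 nM. In this assay, no step beyond the scatter is therefore expected, with a slight lean towards a lower number. The estimate means an expected step of a 1.5-fold lower number from compound 1 to compound 4 (0.18 log units; within the scatter). For compound 4 the estimated value is 3000 nM, with an expected range from 800 nM to 12000 nM.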

Compound 4, half-maximal inhibitory concentration: > 50000 nM
Compound 4: no number, only a limit; the forecaster's own chance of this, stated with the estimate: 8%; middle value at least 16-fold (1.22 log units) away from the limit.
By their numbers in this assay, from the lowest: compound 2; then compound 1; then compound 3.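

In this assay, for the compounds shown here, putting 5-methylfuran-2-yl in place of 2-chlorophenyl on an aromatic carbon next to the ring nitrogen gives an at least 10-fold higher number from compound 1 to compound 4 (1.03 log units; beyond the scatter), the first step here that traces to a change in one place. Compound 4 gives only a limit, not a number: the limit of > 50000 nM in this assay, at which 1 of the 4 values shown sits. Compound 4 keeps both the 5-chlorofuran-2-yl and the thiophen-3-yl groups of compound 1, so this position is not indifferent to what it carries, and those two groups do not by themselves hold the value of compound 1.

On these data alone, whether the step follows the departing chlorine, the change from a six-membered to a five-membered ring or the entering methyl stays open, as this one change alters all three together. Also open, as far as these compounds go, is how a phenyl ring bearing an amine or a carboxylic acid would fare at this position.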